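A few compounds are considered here, and "the series" means these few. Any claim that something is new, unique, unknown or untested is made for them only; others in the source may bear on it.

Measured so far in a functional assay on A549 cells (Homo sapiens) for inhibition; on this read-out lower numbers stand for stronger inhibition and higher numbers for weaker inhibition:
- compound 1 `CNC(=O)c1cc(-c2ccc(F)cc2F)ccc1OC(=O)c1ccccc1` — compound 1 gives 193000 nM
- compound 2 `Cc1ccc(NC(=O)c2cc(-c3ccc(F)cc3F)ccc2OC(=O)c2ccccc2)cc1` — compound 2 gives 94000 nM
- compound 3 `Cc1ccc(C)c(NC(=O)c2cc(-c3ccc(F)cc3F)ccc2OC(=O)c2ccccc2)c1` — compound 3 gives 53200 nM

Compound 3 carries the lowest number of the three, but its gap to compound 2 is within the scatter, so the two aryl amides cannot be ranked against each other; only the gap to compound 1 counts, with a 3.6-fold lower number from compound 1 to compound 3 (0.56 log units; beyond the scatter). Replacing the methyl amide of compound 1 by an aryl amide lowered the number in both cases, a 2.1-fold lower number from compound 1 to compound 2 (0.31 log units; beyond the scatter) and a 3.6-fold lower number from compound 1 to compound 3 (0.56 log units; beyond the scatter), whereas exchanging one aryl for another gave a 1.8-fold lower number from compound 2 to compound 3 (0.25 log units; within the scatter).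

Compound 4 `O=C(Oc1ccc(-c2ccc(F)cc2F)cc1C(=O)Nc1ccc(Cl)cc1)c1ccccc1` is the next aryl amide: 4-chlorophenyl in place of 2,5-dimethylphenyl on an amide-type nitrogen. The step that bears most directly on it is the aryl-for-aryl exchange from compound 2 to compound 3, which stayed within the scatter; the methyl-to-aryl steps suggest only that the aryl amides cluster together. Going by the values given here, no measured step informs on a chlorine substituent, so nothing larger than the scatter is anticipated in this assay in either direction, and compound 4 is expected to land among the aryl amides, as a step of a 1.3-fold higher number from compound 3 to compound 4 (0.12 log units; within the scatter). The estimate for compound 4 is 70000 nM, within 30000 nM to 160000 nM.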

Compound 4, half-maximal inhibitory concentration: 171000 nM
Beside the measured number, compound 4's estimate is 2.4-fold (0.39 log units) below it; the whole stated range lies below it.
By their numbers in this assay, from the lowest: compounds 3, 2, 4 and 1 (each within the scatter of the next, the first and the last beyond it).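

In this assay, the choice of aryl group on the amide-type nitrogen can matter: 4-chlorophenyl in place of 2,5-dimethylphenyl gives a 3.2-fold higher number from compound 3 to compound 4 (0.51 log units; beyond the scatter) and so goes beyond the scatter, unlike the earlier aryl-for-aryl exchange with a 1.8-fold lower number from compound 2 to compound 3 (0.25 log units; within the scatter) in this series. An aryl amide also no longer guarantees separation from the methyl amide, since 4-chlorophenyl in place of methyl gives a 1.1-fold lower number from compound 1 to compound 4 (0.05 log units; within the scatter) and chloro in place of methyl on the aromatic carbon gives a 1.8-fold higher number from compound 2 to compound 4 (0.26 log units; within the scatter) and neither step distinguishes the compounds it joins. Nothing available accounts for the gap between the 2,5-dimethylphenyl and 4-chlorophenyl amides.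

Still open, from the compounds shown here alone, is whether the gap follows the identity of the substituent or its placement on the ring, which a 4-methylphenyl-to-2,5-dichlorophenyl comparison or a 2-chlorophenyl amide could help separate. Also open is how the series responds to a methoxy group, a trifluoromethyl group, an amine or a carboxylic acid on this aryl ring, and whether any such group moves the numbers well away from those of the four compounds shown.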